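Changing the Carbonyl Substituent of Compound 1

The compounds below may be only part of what the source reports. "The series", "measured", "known", "first", "only" and "open" are said of these compounds alone.

Compound 1 `Cc1nn(C(=O)C2CC2)c(N)c1-c1ccc(Cl)c(Cl)c1` was tested in an assay on Sf9 cells for inhibition of inhibitor of nuclear factor kappa-B kinase subunit epsilon (Homo sapiens), read by ADP-Glo, with a stated time of 60 min; a higher number here means a weaker inhibitor, a lower number a stronger inhibitor. In this assay compound 1 gives > 100000 nM, which is a limit of the assay rather than a measured number. Among the measured compounds shown here, compound 2 `Cc1nn(C(=O)C2CC2)c(N)c1-c1ccc(Cl)cc1` is the only other compound measured. In this assay compound 2 gives > 100000 nM, again only a limit. The step that the two limits leave unreadable from compound 1 to compound 2 therefore cannot be sized, since both values sit at the limit of > 100000 nM in this assay, at which 2 of the 2 values shown sit. Compound 3 `Cc1nn(C(=O)OC(C)(C)C)c(N)c1-c1ccc(Cl)c(Cl)c1` alters a different part of compound 1: tert-butoxy in place of cyclopropyl on a carbonyl carbon. For the measured compounds named here, no measured step bears on this change. The step of a number no higher from compound 1 to compound 3 (the limit leaves the size open) is expected to show nothing beyond the scatter. Compound 3 is estimated at 100000 nM, within 30000 nM to 300000 nM.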

Compound 3, half-maximal inhibitory concentration: > 100000 nM
Compound 3: no number, only a limit; the forecaster's own chance of this, stated with the estimate: 85%; the middle value lies on the limit itself.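

Compound 3, like compound 1, gives only a limit, so no step between the two can be read: the limit of > 100000 nM in this assay, at which 3 of the 3 values shown sit.

The compounds shown leave open how strongly any of them inhibits, and whether swapping cyclopropyl for tert-butoxy changes that at all.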